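Notes on the step from compound 2 to compound 3

The source may report more compounds than this note shows. Statements on the series, on what has been measured and on what is new or still open speak of the compounds shown alone.

Of the compounds shown here, two have numbers so far in a functional assay on PC-3 cells (Homo sapiens) for cytotoxicity, read by sulforhodamine B assay, with a stated time of 48 h; on this read-out higher numbers stand for weaker inhibition and lower numbers for stronger inhibition. Compound 1 `CC(=O)N1N=C(c2ccco2)CC1c1cccc(O)c1` gives 16500 nM, and compound 2 `O=CCN1N=C(c2ccc3ccccc3c2)CC1c1cccc([N+](=O)[O-])c1` gives 2980 nM. Compound 2 therefore holds the lower of the two numbers, and its gap to compound 1 lies beyond the scatter.

The unmeasured compound 3 `COc1ccc(C2CC(c3ccc4ccccc4c3)=NN2CC=O)cc1` keeps the core of compound 2 and carries 4-methoxyphenyl in place of 3-nitrophenyl on a saturated ring carbon. The series offers no measured change at a single place to lean on, so the expectation is anchored only on compound 2 at 2980 nM. In this assay a small move towards a higher number is expected, and it may well stay within the scatter. The estimated change is a 1.5-fold higher number from compound 2 to compound 3 (0.18 log units; within the scatter). For compound 3 the estimated value is 4500 nM, with an expected range of 1500 nM to 14000 nM.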

Compound 3, half-maximal inhibitory concentration: 4530 nM
For compound 3 the middle estimate is 1.0-fold (0.00 log units) below the measured one; the range from low to high includes it.
By their numbers in this assay, from the lowest: compounds 2 and 3 (each within the scatter of the next); then compound 1.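

In this assay the series now has its first change at a single place, on a saturated ring carbon next to the ring nitrogen: a 1.5-fold higher number from compound 2 to compound 3 (0.18 log units; within the scatter) for 4-methoxyphenyl in place of 3-nitrophenyl. Within the scatter, this position therefore accepts either group with the six-membered aromatic ring of carbon only retained, even though the exchange goes from 2 hydrogen-bond acceptors in the group that leaves to 1 hydrogen-bond acceptor in the group that enters. No measured property or other evidence bears on this result, so the step stands as an observation only.

The step changes both the substituent and its place on the phenyl ring, so it does not show how this position would respond to each change alone, or to an amine or a carboxylic acid in place of the methoxy group. Among the compounds shown here, compound 1 differs from compound 2 and compound 3 in more than one place, so no steps to it can be read, and a longer chain in place of the formylmethyl group remains an open question for the shared core.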